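The source may report more compounds than this note shows. Statements on the series, on what has been measured and on what is new or still open speak of the compounds shown alone.

The series rests on a shared core, carried by compound 1 `N#Cc1ccc(NC(=O)c2ccc(-c3cccnc3)cc2O)cc1` and compound 2 `N#Cc1ccc(NC(=O)c2ccc(Br)cc2O)cc1`. In a functional assay on HL-60 cells (Homo sapiens) for cytotoxicity, read by luminescence and CellTiter-Glo, with a stated time of 3 days (on this read-out lower numbers stand for stronger inhibition and higher numbers for weaker inhibition), compound 1 gives 6660 nM, and in this assay compound 2 gives 1210 nM. Between the two lies a single step, a 5.5-fold lower number from compound 1 to compound 2 (0.74 log units; beyond the scatter), so compound 2 stands with the lower of the two numbers measured so far. Compound 3 `N#Cc1ccc(NC(=O)c2ccc(C(F)(F)F)cc2O)cc1` differs from compound 2 in one place: trifluoromethyl in place of bromo on an aromatic carbon. Among the measured compounds shown here, no measured step exchanges bromo for trifluoromethyl. For the measured compounds named here, the only step known, a 5.5-fold lower number from compound 1 to compound 2 (0.74 log units; beyond the scatter), concerns a different group on an aromatic carbon and shows that what sits there can move the number, but it does not tell which way trifluoromethyl would move it. The expected step in this assay is therefore set within the usual scatter, a 1.2-fold higher number from compound 2 to compound 3 (0.09 log units; within the scatter), with wide margins left on either side for the lack of a closer precedent. Compound 3 is estimated at 1500 nM, in a range expected to run from 500 nM to 5000 nM.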

Compound 3, half-maximal inhibitory concentration: 1030 nM
Compound 3: middle estimate off by 1.5-fold (0.16 log units), on the high side, and the stated range covers the measured number.
By their numbers in this assay, from the lowest: compounds 3 and 2 (each within the scatter of the next); then compound 1.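

At the aromatic carbon para to a large group and meta to a hydroxy group, the exchange of bromo for trifluoromethyl gives a step that stays within the scatter in this assay (a 1.2-fold lower number from compound 2 to compound 3 (0.07 log units; within the scatter)), so compound 2 and compound 3 cannot be told apart even though one heavy atom gives way to four. Replacing pyridin-3-yl with trifluoromethyl gives a step beyond the scatter (a 6.5-fold lower number from compound 1 to compound 3 (0.81 log units; beyond the scatter)), and this now stands alongside the earlier step from pyridin-3-yl to bromo (a 5.5-fold lower number from compound 1 to compound 2 (0.74 log units; beyond the scatter)), so two different groups in place of pyridin-3-yl both give a lower number by a similar margin. No measurement that could account for these numbers accompanies the three compounds.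

As far as these compounds go, whether an amine, a carboxylic acid or a methoxy group at this position would read with bromo and trifluoromethyl or with pyridin-3-yl remains open. From the compounds shown here alone, all three compounds carry the same nitrile, hydroxy group and amide, so what each of these contributes to the numbers also stays open.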